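Swapping the iodophenyl for a pyridyl on the thiourea

The compounds below may be only part of what the source reports. "The series", "measured", "known", "first", "only" and "open" are said of these compounds alone.

The series shares one core, shown in compound 1 `NC(=O)c1c(NC(=O)c2ccccc2Cl)sc2c1CCN(Cc1c(Cl)cccc1Cl)C2`, compound 2 `NC(=O)c1c(NC(=O)c2ccc(C(F)(F)F)cc2)sc2c1CCN(Cc1ccccc1F)C2`, and compound 3 `NC(=O)c1c(NC(=O)c2ccccc2Cl)sc2c1CCN(C(=S)Nc1ccccc1I)C2`. In a functional assay on HeLa cells (Homo sapiens) for antiproliferative activity, with a stated time of 24 h (a lower number here means a stronger inhibitor, a higher number a weaker inhibitor), compound 1 gives 28800 nM. In this assay compound 2 reaches only a limit of the assay, > 50000 nM. In this assay compound 3 gives 29000 nM, the highest of the two numbers, with compound 1 as its nearest neighbour; the step of a 1.0-fold higher number from compound 1 to compound 3 (0.00 log units; within the scatter) shows no change beyond the scatter when the whole group on the ring amine is exchanged. The step to compound 4 `NC(=O)c1c(NC(=O)c2ccccc2Cl)sc2c1CCN(C(=S)Nc1cccnc1)C2` is the change (pyridin-3-yl in place of 2-iodophenyl on an amide-type nitrogen). For the measured compounds named here, no measured step touches the aryl group on the thiourea itself; the only related step, a 1.0-fold higher number from compound 1 to compound 3 (0.00 log units; within the scatter), was flat, so no shift beyond the scatter is expected in this assay. Compound 4 is therefore estimated at 35000 nM, in the range 12000 nM to 100000 nM, and the expected step of a 1.2-fold higher number from compound 3 to compound 4 (0.08 log units; within the scatter) is within the scatter.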

Compound 4, half-maximal inhibitory concentration: > 50000 nM
Compound 4 was reported as a limit (the forecaster's own chance of this, stated with the estimate: 30%); at least 1.4-fold (0.15 log units) between middle value and limit.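

In this assay compound 4 gives > 50000 nM, which is a limit of the assay and not a number. From the compounds shown here alone, on the aryl group of the thiourea, an at least 1.7-fold higher number from compound 3 to compound 4 (0.23 log units; that floor lies within the scatter) gives only a floor, so the true size of the change from 2-iodophenyl to pyridin-3-yl stays unknown, and the same holds for the exchange of the whole group on the ring amine, an at least 1.7-fold higher number from compound 1 to compound 4 (0.23 log units; that floor lies within the scatter). This position can therefore be read only up to a fixed ceiling: the limit of > 50000 nM in this assay, at which 2 of the 4 values shown sit.

The compounds shown leave open whether the outcome follows the arrival of the pyridine ring nitrogen or the departure of the iodine. A plain phenyl or a 2-chlorophenyl on the thiourea would separate these two parts of the change.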